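The compounds below may be only part of what the source reports. "The series", "measured", "known", "first", "only" and "open" are said of these compounds alone.

In a functional assay on HCT-116 cells (Homo sapiens) for inhibition, read by MTT assay, with a stated time of 48 h (a lower number here means a stronger inhibitor, a higher number a weaker inhibitor), compound 1 `COc1cc(-c2cc(-c3ccc(Cl)cc3)nc(-c3ccccc3)n2)cc(OC)c1OC` gives 7980 nM. Compound 2 `COc1ccc(-c2cc(-c3cc(OC)c(OC)c(OC)c3)nc(-c3ccccc3)n2)c(OC)c1` reads > 25000 nM, which is only a limit of the assay and not a number. The change under study leads to compound 3 `COc1cc(-c2cc(-c3cccc(O)c3)nc(-c3ccccc3)n2)cc(OC)c1OC`: 3-hydroxyphenyl in place of 2,4-dimethoxyphenyl on an aromatic carbon. In words, 3-hydroxyphenyl stands in place of 2,4-dimethoxyphenyl on the same aromatic carbon that varies between compound 1 and compound 2. Within the data shown here, the only measured step at this place is an at least 3.1-fold higher number from compound 1 to compound 2 (0.49 log units; beyond the scatter), and its size is bounded by the limit. Among the measured compounds shown here, no measured compound carries 3-hydroxyphenyl, so the expectation is only that losing 2,4-dimethoxyphenyl brings the series back towards compound 1 at 7980 nM. The expected change is an at least 2.5-fold lower number from compound 2 to compound 3 (0.39 log units; beyond the scatter), towards a lower number in this assay. For compound 3 the estimated value is 10000 nM, with an expected range of 3000 nM to 25000 nM.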

Compound 3, half-maximal inhibitory concentration: 20400 nM
For compound 3 the middle estimate is 2.0-fold (0.31 log units) below the measured one, within the range that was stated.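

In this assay, the step of a 2.6-fold higher number from compound 1 to compound 3 (0.41 log units; beyond the scatter) shows that replacing 4-chlorophenyl with 3-hydroxyphenyl at this aromatic carbon gives a weaker inhibitor, so losing 2,4-dimethoxyphenyl does not by itself return the series to the level of compound 1. Compound 2 reads > 25000 nM in this assay, which is a limit and not a number. The step of an at least 1.2-fold lower number from compound 2 to compound 3 (0.08 log units; that floor lies within the scatter) therefore gives only a floor, and no gain from the exchange can be claimed because that floor rests on a limit: the limit of > 25000 nM in this assay, at which 1 of the 3 values shown sits.

The compounds shown leave open whether any group at this place can improve on 4-chlorophenyl, and whether the hydroxyl or its location drives the reading for compound 3. An unsubstituted phenyl, a 4-hydroxyphenyl or a 3-aminophenyl would separate these questions.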